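This account rests on a few compounds, and the source may have more. Where it says the series, first, only, none or still open, it means among the compounds named here.

Compound 1 `CSCc1ccc(Nc2ncc(Cc3c(F)cccc3F)o2)cc1` and compound 2 `Fc1cccc(F)c1Cc1cnc(Nc2ccc(Oc3ccncc3)cc2)o1` are the two measured compounds. In an ADME assay on MT2 cells (Homo sapiens) for cytotoxicity, read by MTT assay (a higher number here means that more compound is tolerated, a lower number that less compound is tolerated), compound 1 gives only a limit, > 100000 nM. In this assay compound 2 gives 21000 nM. Compound 2 therefore holds the only number shown, the other value being a limit (the limit of > 100000 nM in this assay, at which 1 of the 2 values shown sits). Compound 3 `Fc1cccc(F)c1Cc1cnc(Nc2ccc(COCc3ccco3)cc2)o1` carries ((furan-2-yl)methoxy)methyl in place of (pyridin-4-yl)oxy on an aromatic carbon. Within the data shown here, the single measured step at this position, an at least 4.7-fold lower number from compound 1 to compound 2 (0.67 log units; beyond the scatter), bears on it, and since compound 1 sits at a limit (the limit of > 100000 nM in this assay, at which 1 of the 2 values shown sits), its size is only known as a minimum. A step back toward more tolerance, a 1.9-fold higher number from compound 2 to compound 3 (0.28 log units; within the scatter), is expected, with wide uncertainty. Compound 3 is estimated at 40000 nM, between 15000 nM and 100000 nM.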

Compound 3, half-maximal cytotoxic concentration: 31000 nM
Compound 3: the middle estimate sits 1.3-fold (0.11 log units) above what was measured; the range from low to high includes it.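

In this assay, the new group brings a 1.5-fold higher number from compound 2 to compound 3 (0.17 log units; within the scatter), so ((furan-2-yl)methoxy)methyl and (pyridin-4-yl)oxy cannot be told apart on this aromatic carbon. Measured against compound 1, the same group gives an at least 3.2-fold lower number from compound 1 to compound 3 (0.50 log units; beyond the scatter), so compound 2 and compound 3 both lie beyond the scatter from compound 1. That second step is only a minimum, since compound 1 stands at a limit: the limit of > 100000 nM in this assay, at which 1 of the 3 values shown sits.

Going by these compounds, how far compound 1 truly lies from the other two stays open. So does how an amine or a carboxylic acid on this aromatic carbon would read in this assay.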